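A few compounds are considered here, and "the series" means these few. Any claim that something is new, unique, unknown or untested is made for them only; others in the source may bear on it.

Compound 3 `CCSc1nnc(-c2cc(OC)c(OC)c(OC)c2)n1-c1ccc(N(C)C)cc1` is the starting point for the step followed here. In a functional assay on HT-29 cells (Homo sapiens) for inhibition, read by MTT assay, with a stated time of 48 h (on this read-out higher numbers stand for weaker inhibition and lower numbers for stronger inhibition), compound 3 gives only a limit of the assay, > 60000 nM. Compound 1 `CCSc1nnc(-c2cc(OC)c(OC)c(OC)c2)n1-c1ccc(OC)cc1` also reaches only a limit in this assay, > 60000 nM. Compound 2 `COc1ccc(-n2c(SCC(=O)c3ccc4ccccc4c3)nnc2-c2cc(OC)c(OC)c(OC)c2)cc1` gives a number in this assay, 53400 nM. Two of the three values shown are therefore no more than the limit of > 60000 nM in this assay, at which 2 of the 3 values shown sit, so the whole set is read against that ceiling. The step that the two limits leave unreadable from compound 1 to compound 3 cannot be sized, and the step of an at least 1.1-fold lower number from compound 1 to compound 2 (0.05 log units; that floor lies within the scatter) does not leave the scatter.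

Compound 4 `COc1ccc(NC(=O)CSc2nnc(-c3cc(OC)c(OC)c(OC)c3)n2-c2ccc(N(C)C)cc2)cc1` differs from compound 3 by (4-methoxyphenyl)carbamoyl in place of methyl on a saturated chain carbon bound to a sulfur. Among the compounds with values here, the nearest precedent is the step of an at least 1.1-fold lower number from compound 1 to compound 2 (0.05 log units; that floor lies within the scatter), a change at the same saturated chain carbon bound to a sulfur, which produced nothing readable beyond the scatter; the step that the two limits leave unreadable from compound 1 to compound 3 fixes where compound 3 starts but gives no size. No movement beyond the scatter is therefore expected in this assay. Compound 4 is expected to give about 50000 nM in this assay, within a range from 12000 nM to 60000 nM. That estimate means a step of an at least 1.2-fold lower number from compound 3 to compound 4 (0.07 log units; that floor lies within the scatter), expected to be small, and a limit rather than a number remains quite possible.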

Compound 4, half-maximal inhibitory concentration: 51400 nM
Beside the measured number, compound 4's estimate is 1.0-fold (0.01 log units) below it; the range from low to high includes it.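

Placing (4-methoxyphenyl)carbamoyl on the saturated chain carbon bound to a sulfur in this assay gives an at least 1.1-fold lower number from compound 3 to compound 4 (0.06 log units; that floor lies within the scatter). Compound 3 reads only as a limit, > 60000 nM. This is a second large group at this place, now on the dimethylamino member of the series, and compound 4 gives a number, but the true size of the step stays unknown because its starting value is a ceiling: the limit of > 60000 nM in this assay, at which 2 of the 4 values shown sit.

Open, going by these compounds, is whether a carboxylic acid or an amine at the same chain carbon would bring a step beyond the scatter. Also open, on these data alone, is how (4-methoxyphenyl)carbamoyl reads with methoxy in place of dimethylamino on the aromatic carbon, and the step between the two ethylthio limit compounds cannot be read.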